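The source may hold more compounds than are shown below. What is called first, only, known or untested is meant among the compounds shown, and "the series" means these compounds.

Compound 1 `C=C[C@@](C)(/C=C/c1ccc(OS(=O)(=O)C(F)(F)F)cc1)CCC=C(C)C`, compound 2 `C=C[C@@](C)(/C=C/c1ccc(OS(=O)(=O)c2ccc(C)cc2)cc1)CCC=C(C)C` and compound 3 `C=C[C@@](C)(/C=C/c1ccc(O)cc1)CC/C=C(C)/C=C/C(=O)OCc1ccccc1` are the measured compounds. In a functional assay on HepG2 cells (Homo sapiens) for cytotoxicity, with a stated time of 72 h (a higher number here means that more compound is needed for the effect, a lower number that less compound is needed), compound 1 gives > 52000 nM, which is a limit of the assay rather than a number. Compound 2 gives > 52000 nM, again a limit. Compound 3 gives > 52000 nM, once more a limit. Compound 1 therefore stands at the limit of > 52000 nM in this assay, at which 3 of the 3 values shown sit. Among the compounds with values here, the one measured step, a step that the two limits leave unreadable from compound 1 to compound 2, has no readable size. Compound 4 `C=C[C@@](C)(/C=C/c1ccc(Nc2ccc(Cl)c(Cl)c2)cc1)CCC=C(C)C` differs from compound 1 as (3,4-dichlorophenyl)amino in place of ((trifluoromethyl)sulfonyl)oxy on an aromatic carbon. Within the data shown here, no measured step speaks to this change in this assay, so the estimated step of an at least 1.3-fold lower number from compound 1 to compound 4 (0.11 log units; that floor lies within the scatter) rests on the shared limit alone and carries no supported direction. Compound 4 is expected at 40000 nM, within a range from 8000 nM to 120000 nM.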

Compound 4, half-maximal effective concentration: > 52000 nM
Compound 4 ended at the assay's limit (the forecaster's own chance of this, stated with the estimate: 55%); middle value at least 1.3-fold (0.11 log units) away from the limit.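

The step from compound 1 to compound 4 cannot be read, as both compounds give only a limit and not a number: the limit of > 52000 nM in this assay, at which 4 of the 4 values shown sit.

The compounds shown leave open whether they truly differ in this assay, and which change to the shared core would give a readable number.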